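The compounds below may be only part of what the source reports. "The series", "measured", "known", "first", "only" and "open" are said of these compounds alone.

Measured so far in a functional assay on SEM cells (Homo sapiens) for cytotoxicity, with a stated time of 72 h (on this read-out lower numbers stand for an effect already at smaller amounts and higher numbers for an effect only at larger amounts of compound), each entry being a limit of the assay and not a number:

- compound 1 `C=C[C@@](C)(/C=C/c1ccc(O)cc1)CCC=O`: > 36600 nM
- compound 2 `C=C[C@@](C)(/C=C/c1ccc(O)cc1)CC/C=C/C(=O)c1ccccc1`: > 36600 nM
- compound 3 `C=C[C@@](C)(/C=C/c1ccc(O)c(/C=C/C(=O)OCC)c1)CCC=C(C)C`: > 36600 nM

The three compounds cannot be ranked, and the common result is the limit of > 36600 nM in this assay, at which 3 of the 3 values shown sit. Compound 3 stands at > 36600 nM, which is a limit, so there is no number to start from.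

Compound 4 `C=C[C@@](C)(/C=C/c1ccc(O)c(/C=C/c2ccc(F)cc2)c1)CCC=C(C)C` differs from compound 3 in one place: 4-fluorophenyl in place of ethoxycarbonyl on a double-bonded chain carbon bound to a double-bonded chain carbon. In words, 4-fluorophenyl stands in place of ethoxycarbonyl on a double-bonded chain carbon bound to a double-bonded chain carbon. The same change can be read as 2-(ethoxycarbonyl)ethenyl becoming 2-(4-fluorophenyl)ethenyl.

Among the measured compounds shown here, no measured pair shows what a single change does in this assay, so this expectation is a cautious one. The expected step of an at least 1.4-fold lower number from compound 3 to compound 4 (0.16 log units; that floor lies within the scatter) is modest and points toward lower numbers, though it may not show at all. The assay may well report a limit again, as it did for compound 3 at > 36600 nM. If a number does appear, the estimated value for compound 4 is 25000 nM, with an expected range from 8000 nM to 50000 nM.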

Compound 4, half-maximal effective concentration: > 36600 nM
Compound 4 gave a limit, no number; the forecaster's own chance of this, stated with the estimate: 60%; at least 1.4-fold (0.16 log units) between middle value and limit.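

In this assay compound 4 gives > 36600 nM, which is a limit and not a number. Compound 3 also stands at a limit, so no step can be read between compound 3 and compound 4. The compounds shown share one result: the limit of > 36600 nM in this assay, at which 4 of the 4 values shown sit.

What a single change does to the effect in this assay stays open, as does any ranking of these compounds.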